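A few compounds are considered here, and "the series" means these few. Any claim that something is new, unique, unknown or untested is made for them only; others in the source may bear on it.

Compound 3 `COC(=O)Nc1c(N)nc(-c2nn(Cc3ccccc3F)c3ncccc23)nc1N` gives 0.3 uM in an assay on cells for activation of Guanylate cyclase soluble subunit alpha-1 (Rattus norvegicus), read by cGMP accumulation and immunoassay, with a stated time of 10 min (a higher number here means that more compound is needed for the effect, a lower number that less compound is needed), level with compound 2 `COC(=O)N(CCO)c1c(N)nc(-c2nn(Cc3ccccc3F)c3ncccc23)nc1N`, which gives 0.3 uM, and together they hold the highest numbers of the three measured. Compound 1 `CCN(C(=O)OC)c1c(N)nc(-c2nn(Cc3ccccc3F)c3ncccc23)nc1N` gives 0.2 uM. Moving from compound 1 to compound 2 shows a 1.5-fold higher number from compound 1 to compound 2 (0.18 log units; within the scatter), from compound 1 to compound 3 a 1.5-fold higher number from compound 1 to compound 3 (0.18 log units; within the scatter), and from compound 2 to compound 3 no change at the digits printed from compound 2 to compound 3 (within the scatter). Compound 4 `CC(C)OC(=O)Nc1c(N)nc(-c2nn(Cc3ccccc3F)c3ncccc23)nc1N` is the next candidate; it differs from compound 3 in that (isopropyl in place of methyl on an oxygen next to a carbonyl group). Among the compounds with values here, none of the measured steps touches this part of the molecule: all three concern the amide-type nitrogen, so no step directly bears on the change from (methoxycarbonyl)amino to (isopropoxycarbonyl)amino. What the measured steps do show is that variation around this region has so far stayed within the scatter, so a step of similar size, in no definite direction, is expected here. The step from compound 3 to compound 4 is therefore estimated as no change at the digits printed from compound 3 to compound 4 (within the scatter). Compound 4 is expected to give 0.3 uM, with a range from 0.1 uM to 1 uM.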

Compound 4, minimum effective concentration: 0.8 uM
Estimate against measurement, compound 4: 2.7-fold (0.43 log units) below; the range from low to high includes it.
By their numbers in this assay, from the lowest: compounds 1, 2 and 3 (each within the scatter of the next); then compound 4.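

Within the data shown here, putting isopropyl in place of methyl on an oxygen next to a carbonyl group gives a 2.7-fold higher number from compound 3 to compound 4 (0.43 log units; beyond the scatter) in this assay and is the first step that lies beyond the scatter. Compound 4 also stands apart from the two compounds substituted on the amide-type nitrogen, with a 2.7-fold higher number from compound 2 to compound 4 (0.43 log units; beyond the scatter) and a 4.0-fold higher number from compound 1 to compound 4 (0.60 log units; beyond the scatter), whereas the changes on that nitrogen among compound 1, compound 2 and compound 3 all stayed within the scatter. Nothing shown here gives a reason for this step.

The compounds leave open how the number follows the group on that oxygen, which ethyl, tert-butyl or benzyl there would help to settle. They also leave open whether ethyl or 2-hydroxyethyl on the amide-type nitrogen would give the same step when combined with isopropyl on the oxygen.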